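The source may hold more compounds than are shown below. What is called first, only, known or untested is meant among the compounds shown, and "the series" means these compounds.

The four compounds share a fluorinated benzyl thioether attached to one of two cores. Compound 1 `Fc1ccccc1CSc1nnc(-c2cnccn2)o1` and compound 2 `Fc1cccc(F)c1CSc1nnc(-c2cnccn2)o1` share the core of compound 1, while compound 3 `Fc1ccc(CSc2nnc(-c3cnccn3)s2)cc1` and compound 4 `Fc1ccc(CSc2nnc(-c3cnccn3)s2)c(F)c1` share the core of compound 3. The difference between the two cores is not broken down here.

In a functional assay on HeLa cells (Homo sapiens) for antiproliferative activity, read by MTT assay, with a stated time of 48 h (a higher number here means a weaker inhibitor, a lower number a stronger inhibitor), compound 1 gives 25300 nM. For compound 2 the reading in this assay is a limit of the assay, > 50000 nM. The change from compound 1 to compound 2 is fluoro in place of hydrogen on an aromatic carbon, and it produced the step of an at least 1.9-fold higher number from compound 1 to compound 2 (0.29 log units; that floor lies within the scatter). Because the limit of > 50000 nM in this assay, at which 2 of the 3 values shown sit, caps the second reading, the size of that step is known only as a floor.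

For compound 3 the reading in this assay is likewise a limit of the assay, > 50000 nM.

Compound 4 has not yet been measured. Going by the values given here, it differs from compound 3 by fluoro in place of hydrogen on an aromatic carbon, which is the same change, at the same kind of place, as the one that separates compound 1 from compound 2. Because an at least 1.9-fold higher number from compound 1 to compound 2 (0.29 log units; that floor lies within the scatter) reached the limit rather than moving the other way, the step expected for compound 4 in this assay is a step that the limit leaves unreadable from compound 3 to compound 4. Compound 4 is therefore estimated at 90000 nM, within an expected span from 30000 nM to 300000 nM, and its reading is expected most likely to come back as a limit again.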

Compound 4, half-maximal inhibitory concentration: 20900 nM
Estimate against measurement, compound 4: 4.3-fold (0.63 log units) above; the whole stated range lies above it.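

In this assay, fluoro in place of hydrogen on an aromatic carbon gave an at least 2.3-fold lower number from compound 3 to compound 4 (0.37 log units; beyond the scatter), so on the core of compound 3 the change did not repeat the direction it took on the core of compound 1: the same change on two cores in this assay, an at least 1.9-fold higher number (0.29 log units; that floor lies within the scatter) from compound 1 to compound 2 and an at least 2.3-fold lower number (0.37 log units; beyond the scatter) from compound 3 to compound 4, at least 4.7-fold (0.67 log units) apart, beyond the scatter of two such steps. The size of each step is known only from one side, since one reading in each pair is a limit of the assay and not a number: the limit of > 50000 nM in this assay, at which 2 of the 4 values shown sit. This shows that, for these two pairs, the effect of this change could not be carried from one core to the other, but it does not show what sets the two steps apart, and one pair on each core gives no rule for any further core.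

The compounds shown leave open whether the same split between the two cores would appear with chloro or methoxy in place of fluoro, on an aromatic carbon ortho to a large group. They also leave open how either core would respond to an amine or a carboxylic acid on the six-membered aromatic ring, or to a longer chain in place of the benzyl thioether.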